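Compound 3: 4-bromo-2-chlorophenyl in place of 2,4-dichloro-5-fluorophenyl

The source may hold more compounds than are shown below. What is called first, only, known or untested is meant among the compounds shown, and "the series" means these compounds.

In an ADME assay on microsomes from liver (Canis lupus familiaris) for metabolic stability (a higher number here means that the compound lasts longer, a lower number that the compound disappears faster), compound 2 `Nc1nc(NCCNc2ncc(-c3ncc[nH]3)c(-c3cc(F)c(Cl)cc3Cl)n2)ccc1[N+](=O)[O-]` gives > 0.5 h as a limit, not a number. Compound 1 `Nc1nc(NCCNc2ncc(-c3ncc[nH]3)c(-c3ccccc3Cl)n2)ccc1[N+](=O)[O-]` gives > 0.5 h as a limit too. Among the measured compounds shown here, the series so far stands at the limit of > 0.5 h in this assay, at which 2 of the 2 values shown sit, and offers no measured number. Compound 3 `Nc1nc(NCCNc2ncc(-c3ncc[nH]3)c(-c3ccc(Br)cc3Cl)n2)ccc1[N+](=O)[O-]` brings 4-bromo-2-chlorophenyl in place of 2,4-dichloro-5-fluorophenyl on an aromatic carbon on the same aromatic carbon. For the measured compounds named here, the one measured step at this place is a step that the two limits leave unreadable from compound 1 to compound 2 and gives no size to carry over. In this assay no step beyond the scatter is expected, with the estimated step being a step that the limit leaves unreadable from compound 2 to compound 3 and no direction assumed. Compound 3 is estimated at 0.6 h within an expected range from 0.3 h to 1.2 h and may again turn out to be only a limit.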

Compound 3, half-life: > 0.5 h
Compound 3 was reported as a limit; the forecaster's own chance of this, stated with the estimate: 70%; the middle value is on the limit's open side.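

No step among compound 1, compound 2 and compound 3 can be read in this assay, as each result is a limit and not a number: the limit of > 0.5 h in this assay, at which 3 of the 3 values shown sit.

The compounds shown leave open the actual half-life of each compound and whether the changes on the phenyl ring alter it at all in this assay.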